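This account rests on a few compounds, and the source may have more. Where it says the series, first, only, none or still open, it means among the compounds named here.

Compound 3 `C/C(=C\C(=O)Nc1ccccc1OCCCC(=O)O)c1ccc2c(ccn2C(CC(C)C)c2ccccc2)c1` gives the lowest number in this set. In an assay on Prostate gland for inhibition of steroid 5-alpha-reductase (Rattus norvegicus) (on this read-out higher numbers stand for weaker inhibition and lower numbers for stronger inhibition), compound 3 gives 6.3 nM, compared with 19 nM for compound 2 `C/C(=C\C(=O)Nc1ccccc1OCCCC(=O)O)c1ccc2c(ccn2C(C)c2ccccc2)c1` and 480 nM for compound 1 `COc1ccc(Cn2ccc3cc(/C(C)=C/C(=O)Nc4ccccc4OCCCC(=O)O)ccc32)cc1`. The step from compound 3 to compound 4 `COc1ccc(C(c2ccccc2)n2ccc3cc(/C(C)=C/C(=O)Nc4ccccc4OCCCC(=O)O)ccc32)cc1` is 4-methoxyphenyl in place of isobutyl on a saturated chain carbon bound to an aromatic carbon and an aromatic nitrogen. Among the measured compounds shown here, two measured steps bear on this position. Going from compound 1 to compound 2 replaced 4-methoxybenzyl with 1-phenylethyl, and a 25-fold lower number from compound 1 to compound 2 (1.40 log units; beyond the scatter); going from compound 2 to compound 3 added isopropyl on the same chain carbon, and a 3.0-fold lower number from compound 2 to compound 3 (0.48 log units; beyond the scatter). Both steps show that putting more on the saturated chain carbon bound to the aromatic carbon and the aromatic nitrogen lowers the number, while compound 1, which carries only a hydrogen and the 4-methoxyphenyl ring on that carbon, stands highest. For the measured compounds named here, compound 4 keeps the chain carbon substituted with two rings, so it is expected to stay well below compound 1, but the data contain no step that swaps an alkyl group for a second aromatic ring there, so the expected step of a 2.4-fold higher number from compound 3 to compound 4 (0.38 log units; beyond the scatter) is a modest rise in the number rather than a gain. On this basis compound 4 is estimated at 15 nM in this assay, with a range from 4 nM to 60 nM.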

Compound 4, half-maximal inhibitory concentration: 8.8 nM
Beside the measured number, compound 4's estimate is 1.7-fold (0.23 log units) above it; measured number inside the range.
By their numbers in this assay, from the lowest: compounds 3 and 4 (each within the scatter of the next); then compound 2; then compound 1.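

In this assay, the place on the saturated chain carbon bound to an aromatic carbon and an aromatic nitrogen accepts a second aromatic ring as readily as an open-chain group: exchanging isobutyl for 4-methoxyphenyl gives a 1.4-fold higher number from compound 3 to compound 4 (0.15 log units; within the scatter), so the two groups cannot be told apart here, even though the entering group has more heavy atoms than the one it replaces and brings a hydrogen-bond acceptor. Among the compounds shown here, the same ring also does better than methyl, with a 2.2-fold lower number from compound 2 to compound 4 (0.33 log units; beyond the scatter), and phenyl in place of hydrogen gives a 55-fold lower number from compound 1 to compound 4 (1.74 log units; beyond the scatter), the first step in the set that puts a group on this carbon while leaving the 4-methoxyphenyl ring in place, so that the large change is tied to that one replacement, whereas the earlier steps from compound 1 also removed the methoxy group. Nothing shown gives a reason for these numbers.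

On these data alone, what a second plain phenyl ring, or a ring carrying an amine or a fluorine in place of the methoxy group, would give on this carbon remains open. So does whether an alkyl chain longer than isobutyl would hold the number at the level of compound 3 and compound 4.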